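Extending the ring-nitrogen substituent of compound 1 with a dimethylamino group

The source may hold more compounds than are shown below. What is called first, only, known or untested is meant among the compounds shown, and "the series" means these compounds.

Compound 1 `CCN1CCN(CCC(=O)Nc2nc3c(C)cccc3s2)CC1` carries an ethyl group on the ring amine nitrogen of the shared core. In an assay on membranes from liver for displacement of a labelled ligand from Sigma intracellular receptor 2 (Rattus norvegicus), read by scintillation counting, with a stated time of 120 min (on this read-out lower numbers stand for stronger inhibition and higher numbers for weaker inhibition), compound 1 gives 1200 nM. Within the three measured compounds it is level with compound 3 `CCCCN1CCN(CCC(=O)Nc2nc3c(C)cccc3s2)CC1`, which gives 1200 nM, and together they carry the highest numbers of the set; compound 2 `Cc1cccc2sc(NC(=O)CCN3CCN(C(C)(C)C)CC3)nc12`, with tert-butyl on the same nitrogen, gives 200 nM, the sole value set apart.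

Compound 4 `Cc1cccc2sc(NC(=O)CCN3CCN(CCN(C)C)CC3)nc12` differs from compound 1 by dimethylamino in place of hydrogen on a saturated chain carbon, two bonds along the chain from an amine nitrogen in a ring. Among the measured compounds shown here, two measured steps bear on this change. The closest is no change at the digits printed from compound 1 to compound 3 (within the scatter), where the chain on the ring nitrogen was lengthened at the same carbon without effect. The step of a 6.0-fold lower number from compound 1 to compound 2 (0.78 log units; beyond the scatter) shows that the group on this nitrogen can move the number, but it concerns branching at the nitrogen itself rather than growth along the chain; a 6.0-fold higher number from compound 2 to compound 3 (0.78 log units; beyond the scatter) returns that gain when the branching is undone. Since compound 4 keeps the linear chain and only lengthens it, the expectation is no step beyond the scatter, a 1.2-fold lower number from compound 1 to compound 4 (0.08 log units; within the scatter).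

The estimate for compound 4 in this assay is therefore 1000 nM, with a range from 400 nM to 3000 nM.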

Compound 4, inhibition constant: > 1000 nM
Compound 4 gave a limit, no number; the forecaster's own chance of this, stated with the estimate: 5%; the middle value sits exactly at the limit.
By their numbers in this assay, from the lowest: compound 2; then compounds 1 and 3 (each within the scatter of the next).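

Compound 4, with 2-(dimethylamino)ethyl on the ring amine nitrogen, gives > 1000 nM in this assay, which is a limit of the assay and not a number: the limit of > 1000 nM in this assay, at which 1 of the 4 values shown sits.

Among the compounds shown here, the one readable comparison is with the tert-butyl compound: 2-(dimethylamino)ethyl in place of tert-butyl gives an at least 5.0-fold higher number from compound 2 to compound 4 (0.69 log units; beyond the scatter), so the lower number of compound 2 is not retained with this linear, amine-bearing chain on the same nitrogen. The steps from compound 1 and compound 3 to compound 4 cannot be read, so the effect of dimethylamino on the saturated chain carbon, two bonds along the chain from the ring amine nitrogen, remains unsized relative to hydrogen or ethyl at that carbon.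

Tert-butyl is the only branched group on this nitrogen in the compounds shown, so isopropyl or cyclohexyl there would be needed to test whether branching at the nitrogen itself goes with the lower number. A hydroxyl group or a morpholine at the same chain carbon would show whether the outcome for compound 4 is specific to dimethylamino or extends to other groups at that place.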